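From a Chlorophenyl Ring to a Pentyl Chain

The compounds below may be only part of what the source reports. "The series", "measured", "known", "first", "only" and "open" are said of these compounds alone.

In a functional assay on HepG2 cells (Homo sapiens) for antiproliferative activity, read by MTT assay (a lower number here means a stronger inhibitor, a higher number a weaker inhibitor), compound 1 (`CC1(C)CCc2cc(C(=O)/C=C/c3ccc(OCc4cn(-c5ccc(Cl)cc5)nn4)cc3)c(O)cc2O1`) is reported as "not active" (no number reported). It therefore has no number from which a step could be counted. Two relatives do have numbers: compound 2 (`CC1(C)CCc2c(ccc(C(=O)/C=C/c3ccc(OCc4cn(-c5ccc(Br)cc5)nn4)cc3)c2O)O1`) gives 136000 nM, and compound 3 (`Cc1c(-n2cc(COc3ccc(/C=C/C(=O)c4ccc5c(c4O)CCC(C)(C)O5)cc3)nn2)cccc1[N+](=O)[O-]`) gives 115000 nM.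

Compound 4 (`CCCCCn1cc(COc2ccc(/C=C/C(=O)c3cc4c(cc3O)OC(C)(C)CC4)cc2)nn1`) keeps the core of compound 1 and differs in one place, with pentyl in place of 4-chlorophenyl on an aromatic nitrogen. A ring thus leaves and an open chain enters.

Among the compounds with values here, only one measured step offers any guidance. Exchanging one aromatic group for another on that nitrogen gave a 1.2-fold lower number from compound 2 to compound 3 (0.07 log units; within the scatter). That step is small, but it never replaces a ring with a chain, so it says little about this change. With no number for compound 1, no size or direction can be fixed for the step to compound 4. The expectation is simply that activity stays weak, with either no number at all or a value in the region of compound 3 at 115000 nM.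

In this assay the estimated value for compound 4 is 90000 nM, with an expected range from 25000 nM to 250000 nM.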

Compound 4, half-maximal inhibitory concentration: 95800 nM
For compound 4 the middle estimate is 1.1-fold (0.03 log units) below the measured one, and the stated range covers the measured number.
By their numbers in this assay, from the lowest: compounds 4, 3 and 2 (each within the scatter of the next).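

In this assay, within the data shown here, compound 1 is reported as "not active" (no number reported) and compound 4 gives 95800 nM, so no step between them can be read. No evidence shown bears on this result. The compounds shown leave open how a pentyl chain compares with a 4-chlorophenyl ring at this nitrogen in this assay.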